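Benzyl substituent swap in a triazine series modulating receptor 68

The compounds below may be only part of what the source reports. "The series", "measured", "known", "first", "only" and "open" are said of these compounds alone.

Measured so far:
compound 1 `Nc1nc(NCc2cccc(F)c2)nc(-c2ccccc2CO)n1` — 4.52
compound 2 `Cc1cccc(CNc2nc(N)nc(-c3ccccc3CO)n2)c1` — 4.4

Two compounds share a core and differ only in the substituent on the benzylic ring. In a functional assay on cells for positive allosteric modulation of G-protein coupled receptor 68 (Homo sapiens), read by a luciferase reporter and cAMP accumulation, with a stated time of 30 min, at pH 6.8 and pH 8.3, in the presence of a further agent that is not named here (a lower number here means a less potent compound, a higher number a more potent compound, by a factor of ten per unit of this negative logarithm), compound 1 gives 4.52, and compound 2 gives 4.4. Going by the values given here, the single step between them, a number 0.12 log units lower from compound 1 to compound 2 (within the scatter), is within the scatter, so the two numbers cannot be ordered; compound 2 simply holds the lower of the two values, with compound 1 as its only neighbour.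

Compound 3 `COc1ccccc1CNc1nc(N)nc(-c2ccccc2CO)n1` has not been measured. It differs from compound 2 by 2-methoxyphenyl in place of 3-methylphenyl on a saturated chain carbon bound to a nitrogen on an aromatic ring. Among the compounds with values here, the only measured step, a number 0.12 log units lower from compound 1 to compound 2 (within the scatter), shows that exchanging one small benzylic-ring substituent for another left the read-out unchanged beyond the scatter. Within the data shown here, no measured pair covers a methoxy group or a change of substituent position, so nothing further bears on this step.

The expectation is therefore a flat step: a number 0.10 log units higher from compound 2 to compound 3 (within the scatter) is estimated to stay within the scatter. Compound 3 is expected to give 4.5, with a likely range from 4 to 5.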

Compound 3, negative logarithm of the antagonist equilibrium constant: 3.99
Estimate against measurement, compound 3: 0.51 log units above, and the stated range ends above it.
By their numbers in this assay, from the lowest: compound 3; then compounds 2 and 1 (each within the scatter of the next).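

In this assay, the group on a saturated chain carbon bound to a nitrogen on an aromatic ring can move the read-out beyond the scatter: 2-methoxyphenyl in place of 3-methylphenyl gives a modest fall (a number 0.41 log units lower from compound 2 to compound 3 (beyond the scatter)), and 2-methoxyphenyl in place of 3-fluorophenyl gives a similar one (a number 0.53 log units lower from compound 1 to compound 3 (beyond the scatter)). The methyl and fluoro exchange between compound 1 and compound 2 stayed within the scatter, so this position tolerates some aryl changes but not all of them, and compound 3 now stands lowest of the three, with its steps to both others beyond the scatter. Nothing available explains this fall.

The change to 2-methoxyphenyl alters both the substituent and its place on the ring, so the compounds shown cannot tell whether the fall goes with the methoxy group, with its place, or with both. Also open, as far as these compounds go, is how the read-out responds to an amine or a carboxylic acid on this phenyl ring, or to a longer chain between the ring and the nitrogen.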